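Pyrrolidine for acetamide on the aminoethyl side chain

The compounds below may be only part of what the source reports. "The series", "measured", "known", "first", "only" and "open" are said of these compounds alone.

Measured compounds, with their numbers in an assay on A549 cells with Cystic fibrosis transmembrane conductance regulator variant F508del (Homo sapiens) as the target, read by fluorescence, with a stated time of 25 min; on this read-out higher numbers stand for an effect only at larger amounts of compound and lower numbers for an effect already at smaller amounts:
compound 1 `CC(=O)NC1CCN(c2nc(-c3ccccn3)nc3c2CN(Cc2ccc(Cl)cc2)CC3)CC1` — 1900 nM
compound 2 `CC(=O)NCCNc1nc(-c2ccccn2)nc2c1CN(Cc1ccc(F)cc1)CC2` — 400 nM

In this assay compound 2 gives 400 nM, the lower of the two numbers; the gap to compound 1 lies beyond the scatter. Among the measured compounds shown here, compounds 1 and 2 differ in more than one place, so their two values show only that compound 2 stands lower, and no single change can be read out of them.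

Compound 3 `Fc1ccc(CN2CCc3nc(-c4ccccn4)nc(NCCN4CCCC4)c3C2)cc1` is not yet measured in this assay. It differs from compound 2 in one place: pyrrolidin-1-yl in place of acetamido on a saturated chain carbon, two bonds along the chain from a nitrogen on an aromatic ring. For the measured compounds named here, no step between measured compounds isolates a change of this kind, so the expected direction rests on the change itself rather than on any measured step. The working expectation is a modest loss or none beyond the scatter, with the step from compound 2 to compound 3 estimated as a 1.5-fold higher number from compound 2 to compound 3 (0.18 log units; within the scatter). Compound 3 is expected to give about 600 nM in this assay, with the estimate ranging from 150 nM to 2400 nM.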

Compound 3, half-maximal effective concentration in the Cystic fibrosis transmembrane conductance regulator assay: 500 nM
For compound 3 the middle estimate is 1.2-fold (0.08 log units) above the measured one; the range from low to high includes it.
By their numbers in the Cystic fibrosis transmembrane conductance regulator assay, from the lowest: compounds 2 and 3 (each within the scatter of the next); then compound 1.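

In the Cystic fibrosis transmembrane conductance regulator assay, compound 2 gives 400 nM and compound 3 gives 500 nM and the step with pyrrolidin-1-yl in place of acetamido on a saturated chain carbon, two bonds along the chain from a nitrogen on an aromatic ring, is a 1.3-fold higher number from compound 2 to compound 3 (0.10 log units; within the scatter), so this position accepts either group without a step beyond the scatter, even though the hydrogen-bond donor and the double bond counted on acetamido are absent from pyrrolidin-1-yl, which brings a five-membered non-aromatic ring instead. In a physicochemical assay for solubility, read by HPLC, with a stated time of 24 h, at pH 7.4, tested at 250 uM (on this read-out higher numbers stand for higher solubility and lower numbers for lower solubility), compound 2 gives 226000 nM and compound 3 gives 196000 nM and the same change reads a 1.2-fold lower number from compound 2 to compound 3 (0.06 log units; within the scatter), so this pair is not separated beyond the scatter on either read-out, a single-place comparison that compounds 1 and 2 could not give. Nothing at hand explains why the two groups read alike.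

Going by these compounds, whether a carboxylic acid, a morpholin-4-yl ring or a longer chain at this place would stay within the scatter of compound 2 remains open. One pair also cannot show whether the change from acetamido to pyrrolidin-1-yl would give a step of the same size on another core.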